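This account rests on a few compounds, and the source may have more. Where it says the series, first, only, none or still open, it means among the compounds named here.

Measured so far in a physicochemical assay for solubility, read by chemiluminescence, measured as kinetic solubility; a lower number here means a less soluble compound, a higher number a more soluble compound
- compound 1 `O=C(C1CCCN1)N1CCC2(CCN(c3nccc(NCc4ccc(Cl)cc4Cl)n3)CC2)C1` gives 79 ug/mL
- compound 2 `O=C([C@H]1CCCCN1)N1CCC2(CCN(c3nccc(NCc4ccc(Cl)cc4Cl)n3)CC2)C1` gives 172 ug/mL
- compound 3 `O=C(c1ccccn1)N1CCC2(CCN(c3nccc(NCc4ccc(Cl)cc4Cl)n3)CC2)C1` gives 17 ug/mL

The middle place of these three belongs to compound 1. Its neighbours lie on either side, with a 2.2-fold higher number from compound 1 to compound 2 (0.34 log units; beyond the scatter) going up and a 4.6-fold lower number from compound 1 to compound 3 (0.67 log units; beyond the scatter) going down.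

Compound 4 `O=C(C1CCCN1)N1CCC2(CCN(c3nccc(NCc4ccc(F)cc4F)n3)CC2)C1` has not been measured yet. Its change from compound 1 is 2,4-difluorophenyl in place of 2,4-dichlorophenyl on a saturated chain carbon bound to a nitrogen on an aromatic ring and it amounts to 2,4-difluorophenyl in place of 2,4-dichlorophenyl on a saturated chain carbon bound to a nitrogen on an aromatic ring.

For the measured compounds named here, no measured step touches this place. All three swap the group on the carbonyl carbon, so they show only how far this assay has moved among these compounds, from a 2.2-fold higher number from compound 1 to compound 2 (0.34 log units; beyond the scatter) up to a 10-fold lower number from compound 2 to compound 3 (1.01 log units; beyond the scatter) in size. The data do not give the direction for the new change, so a small upward move is only a judgement. The expected move is a 1.6-fold higher number from compound 1 to compound 4 (0.22 log units; within the scatter) as estimated here. For compound 4 the estimated value is 130 ug/mL with an expected range from 55 ug/mL to 300 ug/mL in this measurement.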

Compound 4, solubility: 175 ug/mL
For compound 4 the middle estimate is 1.3-fold (0.13 log units) below the measured one; the range from low to high includes it.
By their numbers in this assay, from the lowest: compound 3; then compound 1; then compounds 2 and 4 (each within the scatter of the next).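

Until now, every step in this assay came from the group on the carbonyl carbon; this first change on a saturated chain carbon bound to a nitrogen on an aromatic ring gives a 2.2-fold higher number from compound 1 to compound 4 (0.35 log units; beyond the scatter) and shows that this place also moves the number. Replacing the two chlorine atoms with two fluorine atoms leaves the heavy-atom count and the count of hydrogen-bond donors and acceptors unchanged, yet the step is of modest size, like a 2.2-fold higher number from compound 1 to compound 2 (0.34 log units; beyond the scatter) at the carbonyl carbon. No measurement in hand offers an explanation for this rise.

Plain phenyl, or a phenyl with a single chlorine, at this place would show whether both halogen atoms are needed for the change. Going by these compounds, it also remains open whether 2,4-difluorophenyl would give a similar step alongside piperidin-2-yl or pyridin-2-yl on the carbonyl carbon.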